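This account rests on a few compounds, and the source may have more. Where it says the series, first, only, none or still open, it means among the compounds named here.

Values in a functional assay on MDA-MB-231 cells (Homo sapiens) for inhibition, read by MTT assay, with stated times of 18 h and 4 h; a higher number here means a weaker inhibitor, a lower number a stronger inhibitor:
- compound 1 `CCCCCCCCCCCCCCCCOP(=O)(O)OCCSC(=S)N1CCCCCC1`: > 100000 nM, a limit of the assay
- compound 2 `CCCCCCCCCCOP(=O)(O)OCCSC(=S)N1CCCCCC1`: 11400 nM
- compound 3 `CCCCCCOP(=O)(O)OCCSC(=S)N1CCCCCC1`: 17200 nM

Only two of the three entries are numbers, and they stand together: a 1.5-fold higher number from compound 2 to compound 3 (0.18 log units; within the scatter). The other two steps, an at least 8.7-fold lower number from compound 1 to compound 2 (0.94 log units; beyond the scatter) and an at least 5.8-fold lower number from compound 1 to compound 3 (0.76 log units; beyond the scatter), both start from the limit.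

The next compound is compound 4 `CCCCCCOP(=O)(O)OCCSC(=S)N1CCN(C)CC1`, with 4-methylpiperazin-1-yl in place of azepan-1-yl on a thiocarbonyl carbon.

All three measured steps alter the saturated chain, and none alters the group on the thiocarbonyl carbon. They therefore bear on this change only indirectly and give no direct size for it. Among the measured compounds shown here, with no precedent for a direction, no step beyond the scatter is expected in this assay, and the starting point stays compound 3 at 17200 nM. The expected change is a 1.2-fold higher number from compound 3 to compound 4 (0.07 log units; within the scatter). For compound 4 the estimated value is 20000 nM, with an expected range of 6000 nM to 70000 nM.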

Compound 4, half-maximal inhibitory concentration: 73000 nM
Estimate against measurement, compound 4: 3.7-fold (0.56 log units) below; the whole stated range lies below it.
By their numbers in this assay, from the lowest: compounds 2 and 3 (each within the scatter of the next); then compound 4. At a limit, above all of these: compound 1.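

In this assay the group on the thiocarbonyl carbon proves able to move the number: a 4.2-fold higher number from compound 3 to compound 4 (0.63 log units; beyond the scatter) with 4-methylpiperazin-1-yl in place of azepan-1-yl and the hexyl chain unchanged. Among the compounds shown here, the earlier steps beyond the scatter all altered the saturated chain and all started from a limit, so this is the first such step between two actual numbers. Nothing given here accounts for the step.

The change swaps a seven-membered ring with 1 hetero atom for a six-membered ring with 2 hetero atoms and adds a methyl group, and the compounds shown do not separate these; piperidin-1-yl, morpholin-4-yl or unsubstituted piperazin-1-yl on the same carbon would bear on this. Also open, as far as these compounds go, is whether the step holds with a decyl chain in place of hexyl.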